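A few compounds are considered here, and "the series" means these few. Any claim that something is new, unique, unknown or untested is made for them only; others in the source may bear on it.

Of the compounds shown here, three share one core and have been measured in a functional assay on cells (Cancer cell lines, Homo sapiens) for cytotoxicity, read by sulforhodamine B assay, with a stated time of 48 h; a higher number here means a weaker inhibitor of growth, a lower number a stronger inhibitor of growth. Compound 1 `COc1ccc(C2=NN(C3=NC(=O)/C(=C4\C(=O)Nc5ccccc54)S3)C(c3ccc(OC)cc3)C2)cc1` gives 43900 nM, the highest of the three numbers. Compound 2 `COc1ccc(C2=NN(C3=NC(=O)/C(=C4\C(=O)Nc5ccc(Br)cc54)S3)C(c3ccc(OC)cc3)C2)cc1` gives 200 nM, and compound 3 `COc1ccc(C2CC(c3ccc4ccccc4c3)=NN2C2=NC(=O)/C(=C3\C(=O)Nc4ccccc43)S2)cc1` gives 670 nM. Both measured steps away from compound 1 lower the number by a large amount: a 220-fold lower number from compound 1 to compound 2 (2.34 log units; beyond the scatter), and a 66-fold lower number from compound 1 to compound 3 (1.82 log units; beyond the scatter).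

Compound 4 `COc1ccc(C2=NN(C3=NC(=O)/C(=C4\C(=O)Nc5ccccc54)S3)C(c3ccc(Cl)cc3)C2)cc1` is not yet measured. It differs from compound 1 by chloro in place of methoxy on an aromatic carbon. Neither measured step touches this place: one changes a hydrogen on the ring fused to the lactam, the other swaps the aryl group on the carbon double-bonded to nitrogen. So there is no step of the same kind to lean on. Going by the values given here, the only guide is that each change tried on compound 1 so far has given a lower number, which is thin evidence for a change elsewhere. The expected step is therefore uncertain, with a modest lowering the central guess: a 2.9-fold lower number from compound 1 to compound 4 (0.47 log units; beyond the scatter). On that basis, compound 4 is expected to give about 15000 nM, in a wide range from 2000 nM to 60000 nM.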

Compound 4, concentration for 50% growth inhibition: 77500 nM
Beside the measured number, compound 4's estimate is 5.2-fold (0.71 log units) below it; measured number outside the range, above it.
By their numbers in this assay, from the lowest: compound 2; then compound 3; then compounds 1 and 4 (each within the scatter of the next).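

In this assay, changing 4-methoxyphenyl to 4-chlorophenyl gives a 1.8-fold higher number from compound 1 to compound 4 (0.25 log units; within the scatter), so this swap leaves compound 1 and compound 4 indistinguishable. Going by these compounds alone, this is the first change to compound 1 that stays within the scatter, whereas the bromo change gives a 220-fold lower number from compound 1 to compound 2 (2.34 log units; beyond the scatter) and the naphthalen-2-yl change gives a 66-fold lower number from compound 1 to compound 3 (1.82 log units; beyond the scatter), both large steps made elsewhere on the molecule. No measurement shown here offers an explanation for this difference between the three changes.

With only methoxy and chloro shown at this place, one pair cannot show whether the position is insensitive in general, and an amine or a carboxylic acid there might behave differently. Going by these compounds, it also remains open whether chloro at this place would leave the large step seen with the bromo of compound 2 intact if both changes stood in one molecule.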